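A few compounds are considered here, and "the series" means these few. Any claim that something is new, unique, unknown or untested is made for them only; others in the source may bear on it.

Measured compounds:
compound 1 `N/C(=N\O)c1ccc(C2=C(S(=O)(=O)c3ccccc3)CC(c3ccccc3)(c3ccccc3)O2)cc1` — 30600 nM
compound 2 `CC1(Cc2ccccc2)CC(S(=O)(=O)c2ccccc2)=C(c2ccc(/C(N)=N/O)cc2)O1` — 94600 nM

In an ADME assay on THP-1 cells (Homo sapiens) for cytotoxicity, read by flow cytometry, with a stated time of 72 h (a higher number here means a weaker inhibitor, a lower number a stronger inhibitor), compound 1 gives 30600 nM, the lower of the two numbers at hand. Compound 2 gives 94600 nM in this assay, a gap beyond the scatter. Among the measured compounds shown here, no pair of measured compounds differing in one place is available.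

Compound 3 `N/C(=N\O)c1ccc(C2=C(S(=O)(=O)c3ccc(Nc4ccccc4/C(N)=N/O)cc3)CC(c3ccccc3)(c3ccccc3)O2)cc1` is not yet measured. It differs from compound 1 by a group of 11 heavy atoms (7 carbon, 3 nitrogen, 1 oxygen; one six-membered aromatic ring of carbon only) in place of a hydrogen atom, on an aromatic carbon. For the measured compounds named here, with no comparable step at hand, the expected step of a 1.0-fold lower number from compound 1 to compound 3 (0.01 log units; within the scatter) is none beyond the scatter. Compound 3 is thus estimated at 30000 nM, range 10000 nM to 100000 nM.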

Compound 3, half-maximal inhibitory concentration: > 50000 nM
Compound 3 ended at the assay's limit (the forecaster's own chance of this, stated with the estimate: 25%); middle value at least 1.6-fold (0.22 log units) away from the limit.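

Compound 3 reads > 50000 nM in this assay, a limit of the assay and not a number: the limit of > 50000 nM in this assay, at which 1 of the 3 values shown sits.

Placing the new group on the aromatic carbon para to a large group gives an at least 1.6-fold higher number from compound 1 to compound 3 (0.21 log units; that floor lies within the scatter). This position therefore carries a group of this size with no sign of a lower number, but the floor of the step does not establish a real rise.

Open, as far as these compounds go, are the true value of compound 3 and how a small group on this carbon, such as a methyl or a carboxylic acid, would read.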